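The source may hold more compounds than are shown below. What is called first, only, known or untested is meant among the compounds shown, and "the series" means these compounds.

Compound 1 `CS(=O)(=O)N(CC1CC1)c1ccccc1N1CCN(C(=O)[C@H](CC(=O)N2CCNCC2)Cc2ccc(Cl)cc2)CC1` gives 220 nM in an assay on isolated protein for binding affinity to Melanocortin receptor 4 (Homo sapiens) (on this read-out lower numbers stand for stronger inhibition and higher numbers for weaker inhibition), while compound 2 `CC(=O)N1CCN(C(=O)C[C@H](Cc2ccc(Cl)cc2)C(=O)N2CCN(c3ccccc3N(CC3CC3)S(C)(=O)=O)CC2)CC1` gives 11 nM in this assay. Within the data shown here, the one change between them, acetyl in place of hydrogen on an amine nitrogen in a ring, brought a 20-fold lower number from compound 1 to compound 2 (1.30 log units; beyond the scatter). Compound 3 `CCN(C(C)=O)C(C)c1ccccc1N1CCN(C(=O)[C@H](CC(=O)N2CCC2)Cc2ccc(Cl)cc2)CC1` gives 19 nM in this assay; this is the second highest of the three numbers, within the scatter of compound 2 and well apart from compound 1. Compound 4 `CCN(C(C)=O)C(C)c1ccccc1N1CCN(C(=O)[C@H](CC(=O)NCc2ccccc2F)Cc2ccc(Cl)cc2)CC1` has not yet been measured. It differs from compound 3 by (2-fluorobenzyl)amino in place of azetidin-1-yl on a carbonyl carbon. Among the measured compounds shown here, no measured step makes exactly this change. The nearest evidence is that compound 2 and compound 3, which carry different groups on a carbonyl carbon of the shared core, sit within the scatter of each other, whereas a 20-fold lower number from compound 1 to compound 2 (1.30 log units; beyond the scatter) shows that a change in this part of the molecule can move the number strongly. The chemist therefore expects the number for compound 4 to stay close to that of compound 3, with a 1.3-fold higher number from compound 3 to compound 4 (0.12 log units; within the scatter) as the expected step. The estimate for compound 4 in this assay is 25 nM, with a range from 8 nM to 80 nM.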

Compound 4, half-maximal inhibitory concentration: 13 nM
For compound 4 the middle estimate is 1.9-fold (0.28 log units) above the measured one; low and high end bracket the measured number.
By their numbers in this assay, from the lowest: compounds 2, 4 and 3 (each within the scatter of the next); then compound 1.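

In this assay, (2-fluorobenzyl)amino in place of azetidin-1-yl on this carbonyl carbon gave a 1.5-fold lower number from compound 3 to compound 4 (0.16 log units; within the scatter), so a group of 9 heavy atoms, with an aromatic ring and a hydrogen-bond donor, is tolerated here as well as one of 4 heavy atoms with neither. The large step seen earlier, a 20-fold lower number from compound 1 to compound 2 (1.30 log units; beyond the scatter), came from acetyl on an amine nitrogen in a ring, and this result shows that a sizeable exchange of group on the carbonyl carbon need not move the number beyond the scatter. No measurement at hand accounts for this tolerance.

Going by these compounds, whether the fluorine contributes at all remains open, and only a plain benzylamino group would settle that. How a longer chain such as 2-phenylethylamino, or a carboxylic acid on the benzyl ring, would fare at this carbonyl carbon is also unknown.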